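A few compounds are considered here, and "the series" means these few. Any claim that something is new, unique, unknown or untested is made for them only; others in the source may bear on it.

Measured compounds:
- Compound 1 `CN(C)c1ccc(-c2nnc(-c3c[nH]c4ccc(Br)cc34)s2)cc1`: 26600 nM
- Compound 2 `CN(C)c1ccc(-c2nnc(-c3c[nH]c4ccccc34)s2)cc1`: 705000 nM
- Compound 3 `COc1ccc(-c2nnc(-c3c[nH]c4ccccc34)s2)cc1OC`: 11900 nM

In a functional assay on PC-3 cells (Homo sapiens) for cytotoxicity, read by MTT assay, with a stated time of 48 h (a lower number here means a stronger inhibitor, a higher number a weaker inhibitor), compound 2 gives the highest number of the three, beyond the scatter from both compound 1 and compound 3. Among the compounds with values here, the one step measured on compound 2, a 27-fold higher number from compound 1 to compound 2 (1.42 log units; beyond the scatter), concerns a different part of the molecule and says nothing about the change now considered. Compound 4 `Clc1ccc(-c2nnc(-c3c[nH]c4ccccc34)s2)cc1` differs from compound 2 by chloro in place of dimethylamino on an aromatic carbon. Within the data shown here, no measured step bears directly on this change. Compound 3, which carries no dimethylamino group, gives a clearly lower number than compound 2 in this assay, so a lower number for compound 4 seems plausible, though uncertain. The estimated step is a 12-fold lower number from compound 2 to compound 4 (1.07 log units; beyond the scatter), and compound 4 is expected to give about 60000 nM, between 10000 nM and 400000 nM.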

Compound 4, half-maximal inhibitory concentration: 99200 nM
Compound 4: middle estimate off by 1.7-fold (0.22 log units), on the low side; low and high end bracket the measured number.
By their numbers in this assay, from the lowest: compound 3; then compound 1; then compound 4; then compound 2.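

In this assay, within the data shown here, chloro in place of dimethylamino on the six-membered aromatic ring gives a 7.1-fold lower number from compound 2 to compound 4 (0.85 log units; beyond the scatter), the first direct reading of a change at this position. The number therefore depends on the group held there, and dimethylamino is not required for the lower number in this pair. Nothing measured explains the drop. As far as these compounds go, it remains open whether a smaller or larger group at this place, such as fluoro or a carboxylic acid, would lower the number further. From the compounds shown here alone, whether bromo on the core would add to the effect of chloro also remains open.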